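The compounds below may be only part of what the source reports. "The series", "measured", "known", "first", "only" and "open" are said of these compounds alone.

Going by the values given here, compound 2 `O=C(N[C@H]1CNC1=O)OCc1ccc(C2CCCC2)cc1` gives 71 nM in an assay on HEK293 cells for inhibition of N-acylethanolamine-hydrolyzing acid amidase (Homo sapiens), read by fluorescence, with stated times of 10 min and 50 min (on this read-out lower numbers stand for stronger inhibition and higher numbers for weaker inhibition), the lowest of the two numbers so far, while compound 1 `CC(C)(C)c1ccc(COC(=O)N[C@H]2CNC2=O)cc1` gives 310 nM. Among the compounds with values here, the only step measured on the same aromatic carbon, a 4.4-fold lower number from compound 1 to compound 2 (0.64 log units; beyond the scatter), was modest but beyond the scatter. Compound 3 `CCc1ccc(COC(=O)N[C@H]2CNC2=O)cc1` carries ethyl in place of cyclopentyl on an aromatic carbon. With a single measured step to rest on, the direction for compound 3 is uncertain, but its number is expected to move upward by about a 4.9-fold higher number from compound 2 to compound 3 (0.69 log units; beyond the scatter). Compound 3 is therefore estimated at 350 nM, within a range from 120 nM to 1100 nM in this assay.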

Compound 3, half-maximal inhibitory concentration: 160 nM
Compound 3: middle estimate off by 2.2-fold (0.34 log units), on the high side; the measured number falls inside the stated range.
By their numbers in this assay, from the lowest: compound 2; then compounds 3 and 1 (each within the scatter of the next).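

At this aromatic carbon, the step from cyclopentyl to ethyl (a 2.3-fold higher number from compound 2 to compound 3 (0.35 log units; beyond the scatter)) is modest but beyond the scatter, so compound 2 keeps its place ahead of compound 3. Ethyl and tert-butyl, however, lie within the scatter of each other (a 1.9-fold lower number from compound 1 to compound 3 (0.29 log units; within the scatter)), leaving cyclopentyl as the only one of the three groups set apart from both others. Nothing available explains this difference. On these data alone, whether a smaller ring such as cyclopropyl, or a larger one such as cyclohexyl, would match cyclopentyl remains open. So does the effect of an amine or a carboxylic acid here.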